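Removing the Triazolyl Side Chain from Compound 2

A few compounds are considered here, and "the series" means these few. Any claim that something is new, unique, unknown or untested is made for them only; others in the source may bear on it.

- compound 1 `O=C1c2c[n+]([O-])c3ccccc3c2C(=O)c2c1c1ccccc1n2Cc1cn(CC(O)CO)nn1`: 1070 nM
- compound 2 `O=C1c2c[n+]([O-])c3ccccc3c2C(=O)c2c1c1ccccc1n2Cc1cn(C[C@@H](O)CO)nn1`: 490 nM

In a toxicity assay on L02 cells (Homo sapiens) for cytotoxicity, read by MTT assay, with a stated time of 72 h (a lower number here means a stronger inhibitor, a higher number a weaker inhibitor), compound 2 gives 490 nM, the lower of the two numbers, while compound 1 gives 1070 nM. Compound 3 `O=C1c2c[n+]([O-])c3ccccc3c2C(=O)c2[nH]c3ccccc3c21` carries hydrogen in place of (1-(2,3-dihydroxypropyl)-1H-1,2,3-triazol-4-yl)methyl on an aromatic nitrogen. Going by the values given here, the sole measured step, a 2.2-fold lower number from compound 1 to compound 2 (0.34 log units; beyond the scatter), is modest and concerns only (the fact that one of compounds 1 and 2 is drawn with a defined configuration and the other without, at the place where they differ). It therefore gives no direct measure of this larger change, and in this assay a sizeable step in either direction remains possible. The estimate is a small expected step, a 1.2-fold lower number from compound 2 to compound 3 (0.09 log units; within the scatter), with wide uncertainty. For compound 3 the expected value is 400 nM, with an estimated range from 80 nM to 2000 nM.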

Compound 3, half-maximal inhibitory concentration: 400 nM
The estimate for compound 3 equals the measured number at the digits printed; measured number inside the range.
By their numbers in this assay, from the lowest: compounds 3 and 2 (each within the scatter of the next); then compound 1.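

In this assay, the whole (1-(2,3-dihydroxypropyl)-1H-1,2,3-triazol-4-yl)methyl group can leave the aromatic nitrogen with the number staying within the scatter: the change gives a 1.2-fold lower number from compound 2 to compound 3 (0.09 log units; within the scatter) here. The same change made on the side chain drawn without a configuration gives a 2.7-fold lower number from compound 1 to compound 3 (0.43 log units; beyond the scatter) and is modest. Nothing recorded here accounts for either step. Still open, as far as these compounds go, is how an amine or a carboxylic acid on a longer chain at this nitrogen would read in this assay, compared with hydrogen.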